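The compounds below may be only part of what the source reports. "The series", "measured", "known", "first", "only" and "open" are said of these compounds alone.

In a functional assay on HepG2 cells (Homo sapiens) for cytotoxicity, read by MTT assay, with a stated time of 24 h (a higher number here means a weaker inhibitor, a lower number a stronger inhibitor), compound 1 `O=C(Nc1ccc(C(F)(F)F)cc1)c1cc(Cl)ccc1O` gives 5800 nM. Compound 3 `O=C(Nc1ccc(Cl)c(Cl)c1)c1cc(Br)ccc1O` gives 4100 nM, within the scatter of compound 1. Among the compounds with values here, compound 2 `O=Cc1ccc(O)c(C(=O)Nc2ccc(C(F)(F)F)cc2)c1` gives 17600 nM, and the one measured step is a 3.0-fold higher number from compound 1 to compound 2 (0.48 log units; beyond the scatter), modest in size, with formyl in place of chloro on an aromatic carbon.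

Compound 4 `CC(=O)c1ccc(NC(=O)c2cc(Cl)ccc2O)cc1` carries this change: acetyl in place of trifluoromethyl on an aromatic carbon, para to a large group. The measured step is only an indirect guide, since it involves a different leaving group at a different site of the shared core. Its one link to the new change is that a carbonyl-bearing group enters in both cases. On that thin basis, a modest step towards a higher number is expected in this assay, though a step within the scatter cannot be ruled out. The expected size is a 1.9-fold higher number from compound 1 to compound 4 (0.28 log units; within the scatter). For compound 4 the estimated value is 11000 nM, with an expected range of 4500 nM to 26000 nM.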

Compound 4, half-maximal inhibitory concentration: 7900 nM
The estimate for compound 4 lay 1.4-fold (0.14 log units) above the measured number; the measured number falls inside the stated range.
By their numbers in this assay, from the lowest: compounds 3, 1 and 4 (each within the scatter of the next); then compound 2.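

In this assay the aromatic carbon para to a large group now has a direct reading, and a 1.4-fold higher number from compound 1 to compound 4 (0.13 log units; within the scatter) is the only step at this position among the compounds shown. Trifluoromethyl and acetyl are not told apart here, although acetyl enters with a hydrogen-bond acceptor and trifluoromethyl has none. The earlier step, a 3.0-fold higher number from compound 1 to compound 2 (0.48 log units; beyond the scatter), also brings in a carbonyl-bearing group but lies at a different site of the shared core, and no step beyond the scatter is seen at this position.

No measurement at hand explains either step. Still open, going by these compounds, is whether an amine, a carboxylic acid or a longer chain at this position would give a step beyond the scatter, or whether this position tolerates such groups as it does acetyl.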